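The compounds below may be only part of what the source reports. "The series", "measured", "known", "first", "only" and "open" are said of these compounds alone.

In a functional assay on the whole organism for inhibition, with Rattus norvegicus as the target, read by cytopathic effect and paw edema, at a dose of 100 mg/kg by the oral route (a higher number here means more inhibition at the dose given (going by the name of the read-out), a lower number less inhibition), compound 2 `Cc1ccccc1NC(=O)c1c(O)c2cccnc2n(-c2ccccc2)c1=O` gives 9.8%, and compound 1 `O=C(Nc1cccc([N+](=O)[O-])c1)c1c(O)c2cccnc2n(-c2ccccc2)c1=O` gives 7.4%; the change a number 2.4 percentage points higher from compound 1 to compound 2 (within the scatter) is one the measurement itself cannot tell apart from noise. Compound 3 `O=C(Nc1cccnc1)c1c(O)c2cccnc2n(-c2ccccc2)c1=O` is the next compound to be tested, and it differs from compound 2 by pyridin-3-yl in place of 2-methylphenyl on an amide-type nitrogen. Among the measured compounds shown here, the one measured step that bears on this, a number 2.4 percentage points higher from compound 1 to compound 2 (within the scatter), also exchanged one ring for another on the same amide-type nitrogen and stayed within the scatter, so no step beyond the scatter is expected here, a number 0.2 percentage points higher from compound 2 to compound 3 (within the scatter). Compound 3 is thus estimated to give 10%, between 0% and 25%.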

Compound 3, a percentage reported as inhibition, in the whole organism at one dose (the size of the read-out at that dose, not a potency): 30.8%
The estimate for compound 3 lay 20.8 percentage points below the measured number; measured number above the stated range.
By their numbers in this assay, from the lowest: compounds 1 and 2 (each within the scatter of the next); then compound 3.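

Ring choice on this amide-type nitrogen can clearly move the number in this assay: the change to pyridin-3-yl gives a number 21 percentage points higher from compound 2 to compound 3 (beyond the scatter) with 2-methylphenyl as the starting group and a number 23.4 percentage points higher from compound 1 to compound 3 (beyond the scatter) with 3-nitrophenyl as the starting group. Among these three compounds, only the ring containing a nitrogen atom stands apart, while the two carbon-only rings do not. Nothing measured here explains this gain.

On these data alone, whether the ring nitrogen itself matters, and whether its place in the ring does, stays open. Unsubstituted phenyl, pyridin-2-yl and pyridin-4-yl on the same nitrogen would address those questions.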